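The compounds below may be only part of what the source reports. "The series", "measured", "known", "first", "only" and "open" are said of these compounds alone.

Compound 1 `CCOC(=O)c1cnn(CC(C)O)c1NC(=O)NCc1ccccc1` is the starting point. In a functional assay on cells (Neutrophil, Homo sapiens) for inhibition, with a stated time of 10 min (a higher number here means a weaker inhibitor, a lower number a stronger inhibitor), compound 1 gives 15 nM, the second highest of the three numbers shown. Among the measured compounds shown here, compound 3 `CCOC(=O)c1cnn(C)c1NC(=O)NCc1ccccc1` gives 18 nM, and the step of a 1.2-fold higher number from compound 1 to compound 3 (0.08 log units; within the scatter) is the only single-point change measured. Compound 2 `CCOC(=O)c1cnn(CC(O)CC)c1NC(=O)Nc1cccc2ccccc12` gives 12 nM, but it differs from compound 1 in more than one place, so its value only shows that an aryl group bound directly to the urea nitrogen sits in the same range. The new compound 4 `CCOC(=O)c1cnn(CC(C)O)c1NC(=O)Nc1ccccc1F` carries 2-fluorophenyl in place of benzyl on an amide-type nitrogen. For the measured compounds named here, no measured step touches this nitrogen, so compound 4 is expected to move by about a 1.1-fold lower number from compound 1 to compound 4 (0.03 log units; within the scatter), not beyond the scatter. Compound 4 is therefore estimated at 14 nM, between 5 nM and 40 nM.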

Compound 4, half-maximal inhibitory concentration: 100 nM
The estimate for compound 4 lay 7.1-fold (0.85 log units) below the measured number, outside the stated range (above it).
By their numbers in this assay, from the lowest: compounds 2, 1 and 3 (each within the scatter of the next); then compound 4.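

In this assay, among the compounds shown here, placing 2-fluorophenyl on the amide-type nitrogen in place of benzyl gives a 6.7-fold higher number from compound 1 to compound 4 (0.82 log units; beyond the scatter), the first measured change at this nitrogen, and it shows that this position does not tolerate every group of the same size. For the compounds shown here, the only other step, a 1.2-fold higher number from compound 1 to compound 3 (0.08 log units; within the scatter), lies at a different place and stays within the scatter. Nothing available gives a reason for this shift.

The change removes the benzyl chain carbon and adds fluorine together, so their shares stay unresolved. As far as these compounds go, how plain phenyl on this nitrogen would compare remains open.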